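Three Limits Precede a Bicyclic Sulfonyl Group

The compounds below may be only part of what the source reports. "The series", "measured", "known", "first", "only" and "open" are said of these compounds alone.

Compound 3 `CCN(Cc1ccccc1)C(=O)C1CCN(S(=O)(=O)c2cccnc2)CC1` was run in a functional assay on CHO cells for positive allosteric modulation of muscarinic acetylcholine receptor M5 (Homo sapiens), read by calcium flux; a higher number here means that more compound is needed for the effect, a lower number that less compound is needed. In this assay compound 3 gives only a limit, > 10000 nM. Compound 2 `CCN(Cc1ccccc1)C(=O)C1CCN(S(=O)(=O)c2ccncc2)CC1` likewise gives only a limit, > 10000 nM. Compound 1 `CCN(Cc1ccccc1)C(=O)C1CCN(S(=O)(=O)c2ccc(OC)c(OC)c2)CC1` also returns only limits, > 10000 nM; > 10000 nM (2 entries). The step that the two limits leave unreadable from compound 2 to compound 3 therefore cannot be read, and the measured steps offer nothing beyond (the limit of > 10000 nM in this assay, at which 2 of the 3 values shown sit). Compound 4 `CCN(Cc1ccccc1)C(=O)C1CCN(S(=O)(=O)c2cccc3nsnc23)CC1` differs from compound 3 by a group of 9 heavy atoms (6 carbon, 2 nitrogen, 1 sulfur; one five-membered aromatic ring with 3 hetero atoms, one six-membered aromatic ring of carbon only) in place of a group of 6 heavy atoms (5 carbon, 1 nitrogen; one six-membered aromatic ring with 1 hetero atom), on a sulfonyl sulfur. Among the measured compounds shown here, no measured step bears on this change, so compound 4 is expected to remain near the same limit, and the step of a number no higher from compound 3 to compound 4 (the limit leaves the size open) is expected to lie within the scatter. Compound 4 is estimated at 10000 nM, with a range from 3000 nM to 30000 nM, and most likely only a limit will be reported.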

Compound 4, half-maximal effective concentration: > 10000 nM
Compound 4 ended at the assay's limit; the forecaster's own chance of this, stated with the estimate: 70%; the middle value sits exactly at the limit.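

In this assay, among the compounds shown here, compound 4 gives only a limit, > 10000 nM, so no step to it from compound 2 or compound 3 can be read. The compounds shown leave open whether any sulfonyl group on the shared core gives a measurable value.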